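The source may report more compounds than this note shows. Statements on the series, on what has been measured and on what is new or still open speak of the compounds shown alone.

In a functional assay on MDA-MB-436 cells (Homo sapiens) for antiproliferative activity, read by MTT assay, with a stated time of 24 h (on this read-out higher numbers stand for weaker inhibition and lower numbers for stronger inhibition), three compounds sharing a core have been tested so far. Compound 1 `O=C(O)CC(NC(=O)c1c(Cl)cccc1Cl)c1ccccc1` reads > 100000 nM, which is a limit of the assay and not a number. Compound 3 `O=C(O)CC(NC(=O)c1ccc(Cl)cc1Cl)c1ccccc1F` reads > 100000 nM, which is also a limit. For the measured compounds named here, compound 2 `O=C(O)CC(NS(=O)(=O)c1cc(F)cc(F)c1)c1ccccc1` gives 69400 nM, the only true number in the set. Compound 4 `O=C(O)CC(NS(=O)(=O)c1cc(F)cc(F)c1)c1ccccc1F` differs from compound 2 in one place: fluoro in place of hydrogen on an aromatic carbon. Going by the values given here, no measured pair shows what this change does, so no shift beyond the usual scatter is expected in this assay, and the expectation rests on compound 2 at 69400 nM. The expected step of a 1.0-fold higher number from compound 2 to compound 4 (0.00 log units; within the scatter) is therefore small. For compound 4 the estimated value is 70000 nM, with an expected range of 28000 nM to 100000 nM.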

Compound 4, half-maximal inhibitory concentration: 89300 nM
Compound 4: the middle estimate sits 1.3-fold (0.11 log units) below what was measured, and the stated range covers the measured number.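

In this assay, fluoro in place of hydrogen on an aromatic carbon, ortho to a large group, gives a 1.3-fold higher number from compound 2 to compound 4 (0.11 log units; within the scatter). For the compounds shown here, this is the first measured case of phenyl to 2-fluorophenyl, and at this position the change moves the read-out by no more than the usual scatter. It brings no real gain, and the series stays weak, close to the limit of the assay: the limit of > 100000 nM in this assay, at which 2 of the 4 values shown sit.

Going by these compounds, whether a methoxy group or an amine at this position would shift the number remains open. So does whether fluoro would have any clearer effect on a compound with much stronger inhibition.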